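The compounds below may be only part of what the source reports. "The series", "measured", "known", "first", "only" and "open" are said of these compounds alone.

Compound 1 `COc1ccc(Cl)cc1S(=O)(=O)NC(=O)NC/C=C1\CCCc2cnn(Cc3ccc(Cl)cc3Cl)c21` gives 8 nM in a functional assay on CHO-K1 cells for antagonist activity at prostaglandin E2 receptor EP3 subtype (Homo sapiens), read by TR-FRET and cAMP accumulation, with a stated time of 30 min; on this read-out higher numbers stand for weaker inhibition and lower numbers for stronger inhibition. Compound 2 `O=C(NC/C=C1\CCCc2cnn(Cc3ccc(Cl)cc3Cl)c21)NS(=O)(=O)c1ccc(Cl)cc1` gives 12 nM in this assay.

Compound 2 is separated from compound 1 only by a 1.5-fold higher number from compound 1 to compound 2 (0.18 log units; within the scatter), and the two numbers lie within each other's scatter. Compound 3 `Cc1nc(C)c(S(=O)(=O)NC(=O)NC/C=C2\CCCc3cnn(Cc4ccc(Cl)cc4Cl)c32)s1` carries the change (2,4-dimethyl-1,3-thiazol-5-yl in place of 4-chlorophenyl on a sulfonyl sulfur). Within the data shown here, the one measured step that bears on it is that exchange of aryl groups on the same sulfonyl sulfur, and it stayed within the scatter; no measured pair shows a thiazole there, so nothing argues for a move beyond the scatter. Compound 3 is therefore expected near 15 nM, between 5 nM and 50 nM, a step of a 1.3-fold higher number from compound 2 to compound 3 (0.10 log units; within the scatter) that stays within the scatter.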

Compound 3, half-maximal inhibitory concentration: 4 nM
For compound 3 the middle estimate is 3.8-fold (0.57 log units) above the measured one; measured number below the stated range.
By their numbers in this assay, from the lowest: compounds 3, 1 and 2 (each within the scatter of the next, the first and the last beyond it).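

Unlike the earlier exchange of aryl groups on this sulfonyl sulfur, replacing 4-chlorophenyl with 2,4-dimethyl-1,3-thiazol-5-yl gives a step beyond the scatter in this assay (a 3.0-fold lower number from compound 2 to compound 3 (0.48 log units; beyond the scatter)), so the group at this place can shift the read-out. Measured against the 5-chloro-2-methoxyphenyl group, however, the same thiazole stays within the scatter (a 2.0-fold lower number from compound 1 to compound 3 (0.30 log units; within the scatter)). No measurement shown explains the step. As far as these compounds go, it remains open whether a pyridine ring or a butyl chain on the sulfonyl sulfur would be tolerated, and whether the thiazole needs either methyl group.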